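The source may hold more compounds than are shown below. What is called first, only, known or untested is meant among the compounds shown, and "the series" means these compounds.

Measured so far:
compound 1 `COc1cc(-c2cc(/C=C/C(=O)c3ccc(Cl)c(Cl)c3)[nH]n2)cc(OC)c1OC` — -58%
compound 2 `COc1ccc(-c2cc(/C=C/C(=O)c3ccc(N)cc3)[nH]n2)cc1OC` — -81%
compound 3 `COc1ccc(-c2cc(/C=C/C(=O)c3cc(OC)c(OC)c(OC)c3)[nH]n2)cc1OC` — -69%

Of the compounds shown here, three have been tested in a functional assay on LOX IMVI cells (Homo sapiens) for cytotoxicity, read by sulforhodamine B assay, with a stated time of 48 h, tested at 100 uM; a lower number here means a stronger effect, a higher number a weaker effect of the compound at the concentration tested. Compound 1 `COc1cc(-c2cc(/C=C/C(=O)c3ccc(Cl)c(Cl)c3)[nH]n2)cc(OC)c1OC` gives -58%, the highest of the three numbers. Compound 3 `COc1ccc(-c2cc(/C=C/C(=O)c3cc(OC)c(OC)c(OC)c3)[nH]n2)cc1OC` comes nearest with -69%, a gap beyond the scatter, and compound 2 `COc1ccc(-c2cc(/C=C/C(=O)c3ccc(N)cc3)[nH]n2)cc1OC` lies furthest with -81%, also beyond the scatter. On these numbers compound 1 shows the weakest effect of the three in this assay.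

The next compound, compound 4 `COc1ccc(C(=O)/C=C/c2cc(-c3cc(OC)c(OC)c(OC)c3)n[nH]2)cc1OC`, keeps the shared core of compound 1 and changes one group: 3,4-dimethoxyphenyl in place of 3,4-dichlorophenyl on a carbonyl carbon. Within the data shown here, no pair of measured compounds differs in only this one place, so there is no measured step to lean on. The two compounds carrying methoxy-bearing rings on the carbonyl carbon, compound 2 and compound 3, both sit lower than compound 1, which suggests that this change moves the number down rather than up.

Compound 4 is therefore expected to give a lower number than compound 1, and the step from compound 1 to compound 4 is estimated at a number 10 percentage points lower from compound 1 to compound 4 (within the scatter), near the edge of the scatter. For compound 4 the estimate in this assay is -68%, with a range from -85% to -50%.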

Compound 4, a percentage reported as activity, at one concentration (the size of the read-out at that concentration, not a potency): -79%
Compound 4: the middle estimate sits 11 percentage points above what was measured; measured number inside the range.
By their numbers in this assay, from the lowest: compounds 2, 4 and 3 (each within the scatter of the next, the first and the last beyond it); then compound 1.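

In this assay, among these compounds, replacing 3,4-dichlorophenyl with 3,4-dimethoxyphenyl on a carbonyl carbon gives a number 21 percentage points lower from compound 1 to compound 4 (beyond the scatter), the first step in this set in which only one group changes while the shared core stays fixed. The earlier compounds shown here differed from one another in more than one place, so they could not separate the contribution of this position from that of the rest of the molecule; this pair shows that the group on the carbonyl carbon can, by itself, move the read-out beyond the usual scatter. No measurement available here bears on why the 3,4-dimethoxyphenyl group gives the lower number.

The step rests on a single pair and a single read-out at one concentration, so it gives no potency and does not show whether a plain phenyl, a 4-fluorophenyl or a phenyl carrying a carboxylic acid on the same carbonyl carbon would fall near compound 1 or compound 4. It also leaves open whether the same exchange would produce a similar step if the other aromatic ring on the shared core carried a different group, such as a morpholine.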